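The source may hold more compounds than are shown below. What is called first, only, known or untested is meant among the compounds shown, and "the series" means these compounds.

Compound 1 `O=C(O)CCc1cc(Cc2cccnc2)cc2c1CCC(NS(=O)(=O)c1ccc(Cl)cc1)C2`: 7 nM
Compound 2 `Cc1c(Cc2cccnc2)cc2c(c1CCC(=O)O)CCC(NS(=O)(=O)c1ccc(Cl)cc1)C2`: 610 nM

Going by the values given here, in a functional assay for inhibition, with Homo sapiens as the target (on this read-out higher numbers stand for weaker inhibition and lower numbers for stronger inhibition), compound 2 gives 610 nM, the higher of the two numbers so far and so the weaker inhibition. Compound 3 `O=C(O)CCc1c2c(cc(Cc3cccnc3)c1-c1ccccc1)CC(NS(=O)(=O)c1ccc(Cl)cc1)CC2` has phenyl in place of methyl on an aromatic carbon. Among the compounds with values here, one measured step bears on this. At that same carbon, methyl in place of hydrogen gave an 87-fold higher number from compound 1 to compound 2 (1.94 log units; beyond the scatter), a large rise. No group larger than methyl has been measured there, so a further, more moderate rise in this assay is expected. The estimated step is a 3.3-fold higher number from compound 2 to compound 3 (0.52 log units; beyond the scatter). Compound 3 is estimated at 2000 nM, with an expected range of 350 nM to 10000 nM.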

Compound 3, half-maximal inhibitory concentration: 180 nM
For compound 3 the middle estimate is 11-fold (1.05 log units) above the measured one; the whole stated range lies above it.
By their numbers in this assay, from the lowest: compound 1; then compound 3; then compound 2.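

In this assay, phenyl in place of methyl gives a 3.4-fold lower number from compound 2 to compound 3 (0.53 log units; beyond the scatter) at this aromatic carbon, so the larger group gives stronger inhibition and the number does not simply rise with group size across these compounds. Hydrogen still gives the strongest inhibition of the three, since phenyl in place of hydrogen gives a 26-fold higher number from compound 1 to compound 3 (1.41 log units; beyond the scatter) in the same assay. Nothing available explains why phenyl fares better than methyl here.

Going by these compounds, whether a methoxy group, a chlorine atom or an amine at this carbon would bring the number closer to that of compound 1 remains open. So does whether a pyridine ring would do better or worse than phenyl.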